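The source may hold more compounds than are shown below. What is called first, only, known or untested is meant among the compounds shown, and "the series" means these compounds.

Cytotoxicity notes on the series, read as the half-maximal cytotoxic concentration in an ADME assay on MT4 cells (Homo sapiens) for cytotoxicity, read by MTT assay; a lower number here means that less compound is tolerated, a higher number that more compound is tolerated. Compound 1 `O=C(CSc1nncnc1-c1ccccc1Cl)Nc1ccccn1` gives 172000 nM in this assay. Among the measured compounds shown here, compound 2 `Cc1ccccc1NC(=O)CSc1nncnc1-c1cccc2ccccc12` gives 158000 nM in this assay, a number that sits within the scatter of the one for compound 1, so on these data the two compounds cannot be told apart. Compound 3 `O=C(CSc1nncnc1-c1cccc2ccccc12)Nc1ccccc1F` has not yet been measured in this assay. Compound 3 differs from compound 2 by fluoro in place of methyl on an aromatic carbon. For the measured compounds named here, no measured pair shows what such a change does to the read-out, so nothing points in either direction. The working expectation for the step from compound 2 to compound 3 is a 1.0-fold higher number from compound 2 to compound 3 (0.01 log units; within the scatter), that is, no step beyond the scatter in this assay. Compound 3 is accordingly estimated at 160000 nM in this assay, with a range from 80000 nM to 320000 nM.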

Compound 3, half-maximal cytotoxic concentration: 65000 nM
For compound 3 the middle estimate is 2.5-fold (0.39 log units) above the measured one, and the stated range ends above it.
By their numbers in this assay, from the lowest: compound 3; then compounds 2 and 1 (each within the scatter of the next).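

In this assay, among the compounds shown here, the change from 2-methylphenyl to 2-fluorophenyl gives a 2.4-fold lower number from compound 2 to compound 3 (0.39 log units; beyond the scatter) and is the first step that compares compounds differing in one place. It shows that the read-out responds to what sits on this aromatic carbon, ortho to a large group, although the step is modest and rests on this single pair. No measurement at hand bears on what lies behind the step.

Going by these compounds, whether a chloro, methoxy or amino group on the same carbon would give a lower number still, or one closer to that of compound 2, stays open. Also open, on these data alone, is whether fluoro in place of methyl gives a step of similar size on a core other than that of compound 2.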